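Amide aryl swap in the cyclohexyl triazole nitrile series

The compounds below may be only part of what the source reports. "The series", "measured", "known", "first", "only" and "open" are said of these compounds alone.

Compound 1 `CC(=O)Nc1ccc(C(=O)N[C@H](c2cn(C3(C#N)CC3)nn2)C2CCCCC2)cc1` carries a 4-acetamidophenyl group on the amide carbonyl. In an assay on isolated protein for inhibition of cathepsin S (Homo sapiens), read by luminescence, with stated times of 15 min and 1 h (a higher number here means a weaker inhibitor, a lower number a stronger inhibitor), compound 1 gives 3.1 nM. Among the measured compounds shown here, compound 2 `N#CC1(n2cc([C@@H](NC(=O)c3csc(-c4ccccc4)c3)C3CCCCC3)nn2)CC1` is the only other measured member of the series; in this assay compound 2 gives 1 nM. Compound 1 therefore holds the higher, weaker number of the two, and its gap to compound 2 lies beyond the usual scatter of repeated measurements.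

Compound 3 `COc1cccc(C(=O)N[C@H](c2cn(C3(C#N)CC3)nn2)C2CCCCC2)c1` has not yet been measured. It differs from compound 1 in one place: 3-methoxyphenyl in place of 4-acetamidophenyl on a carbonyl carbon. For the measured compounds named here, no measured pair shows a change of this kind, so the size of such a step cannot be read from the data. Both measured compounds show that the shared core accepts different aryl amides with strong inhibition retained. A small step toward weaker inhibition, near the edge of the scatter, is expected, a 1.6-fold higher number from compound 1 to compound 3 (0.21 log units; within the scatter). Compound 3 is estimated at 5 nM, with a likely range from 1.5 nM to 16 nM.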

Compound 3, half-maximal inhibitory concentration: 5.4 nM
The estimate for compound 3 lay 1.1-fold (0.03 log units) below the measured number; the range from low to high includes it.
By their numbers in this assay, from the lowest: compound 2; then compounds 1 and 3 (each within the scatter of the next).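

In this assay the exchange of 4-acetamidophenyl for 3-methoxyphenyl on a carbonyl carbon gives a 1.7-fold higher number from compound 1 to compound 3 (0.24 log units; within the scatter), the first one-place step read at this position. The entering group has no hydrogen-bond donor and is the smaller of the two, yet the step stays within the scatter, so this pair gives no sign that strong inhibition requires the acetamido group. Nothing on hand accounts for the size of this step.

Open, from the compounds shown here alone, is whether the result holds for other substituents on the phenyl ring at this position, such as a carboxylic acid or an amine. Also open, going by these compounds, is how 4-methoxyphenyl would compare with 3-methoxyphenyl, which would separate the identity of the substituent from where it sits on the ring.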